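This account rests on a few compounds, and the source may have more. Where it says the series, first, only, none or still open, it means among the compounds named here.

Compound 1 `N#Cc1ccc(-c2cc(Cl)cn3c([N+](=O)[O-])c(CS(=O)(=O)c4ccccc4)nc23)cc1`: > 3900 nM
Compound 2 `O=[N+]([O-])c1c(CS(=O)(=O)c2ccccc2)nc2c(-c3ccccc3C(F)(F)F)cc(Cl)cn12`: 22700 nM
Compound 3 `O=[N+]([O-])c1c(CS(=O)(=O)c2ccccc2)nc2c(-c3cccnc3)cc(Cl)cn12`: > 31300 nM

In an ADME assay on HepG2 cells (Homo sapiens) for cytotoxicity, read by MTT assay, with a stated time of 72 h (a lower number here means that less compound is tolerated, a higher number that more compound is tolerated), compound 1 gives > 3900 nM, and this value is a limit of the assay, not a number. Compound 3 gives > 31300 nM, which is also a limit. Going by the values given here, compound 2 gives 22700 nM, the one plain number among the three. Compound 1 thus stands only as a limit, and one of the two other values is a limit as well, so its place among the three cannot be fixed more closely.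

Compound 4 `O=[N+]([O-])c1c(CS(=O)(=O)c2ccccc2)nc2c(-c3ccco3)cc(Cl)cn12` differs from compound 1 in one place: furan-2-yl in place of 4-cyanophenyl on an aromatic carbon. The two steps that leave compound 1 cannot be read: a step that the limit leaves unreadable from compound 1 to compound 2 and a step that the two limits leave unreadable from compound 1 to compound 3. Among the compounds with values here, the one step with readable bounds, an at least 1.3-fold higher number from compound 2 to compound 3 (0.13 log units; that floor lies within the scatter), has a floor that lies within the usual scatter. Within the data shown here, no measured step therefore gives a size or direction to expect for this change, and the three values together only show that all three compounds are tolerated at high concentration.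

Compound 4 is expected to give roughly 20000 nM, within a range from 5000 nM to 60000 nM. The step that the limit leaves unreadable from compound 1 to compound 4 that this estimate implies is expected to stay within the scatter, with a fair chance that only a limit is reported.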

Compound 4, half-maximal cytotoxic concentration: > 3900 nM
Compound 4 gave a limit, no number (the forecaster's own chance of this, stated with the estimate: 50%); the middle value does not contradict the limit.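

In this assay compound 4 gives > 3900 nM, which is a limit of the assay and not a number. Going by these compounds alone, no step to compound 4 from compound 1, compound 2 or compound 3 can be read. On these data alone, what stays open is whether furan-2-yl, 4-cyanophenyl, pyridin-3-yl or 2-(trifluoromethyl)phenyl on this aromatic carbon changes the tolerated concentration in this assay at all.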